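Swapping the Sulfonyl Aryl Ring in a Pancreatic Cancer Series

A few compounds are considered here, and "the series" means these few. Any claim that something is new, unique, unknown or untested is made for them only; others in the source may bear on it.

Of the compounds shown here, three have been tested in a functional assay on MIA PaCa-2 cells (Homo sapiens) for inhibition, read by MTT assay, with a stated time of 72 h; on this read-out higher numbers stand for weaker inhibition of growth and lower numbers for stronger inhibition of growth. Compound 1 `O=S(=O)(NCCCCNCc1ccc(Br)cc1)c1cc(C(F)(F)F)cc(C(F)(F)F)c1` gives 2100 nM, and compound 2 `O=S(=O)(NCCCNCC1COc2ccccc2O1)c1cc(C(F)(F)F)cc(C(F)(F)F)c1` gives 2600 nM. Compound 3 `O=S(=O)(NCCCCCCNCc1ccc(Br)cc1)c1ccccc1F` gives 13300 nM, the highest of the three numbers, and its gaps to compound 1 and to compound 2 both lie beyond the usual scatter of the measurement. Compound 4 `Cc1ccc(C)c(S(=O)(=O)NCCCCCCNCc2ccc(Br)cc2)c1` differs from compound 3 in one place: 2,5-dimethylphenyl in place of 2-fluorophenyl on a sulfonyl sulfur. For the measured compounds named here, no measured pair isolates this change, so the expectation rests on the one anchor, compound 3. A modest move toward a lower number in this assay is expected, and the step from compound 3 to compound 4 is estimated as a 1.7-fold lower number from compound 3 to compound 4 (0.22 log units; within the scatter). Compound 4 is therefore expected to give about 8000 nM, within a range from 3000 nM to 25000 nM.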

Compound 4, concentration for 50% growth inhibition: 12000 nM
Compound 4: middle estimate off by 1.5-fold (0.18 log units), on the low side; low and high end bracket the measured number.
By their numbers in this assay, from the lowest: compounds 1 and 2 (each within the scatter of the next); then compounds 4 and 3 (each within the scatter of the next).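

In this assay, the exchange of 2-fluorophenyl for 2,5-dimethylphenyl on a sulfonyl sulfur gives a 1.1-fold lower number from compound 3 to compound 4 (0.04 log units; within the scatter). For the compounds shown here, this is the first pair to isolate this position, and on this read-out the two aryl groups cannot be told apart. Nothing available here explains this result.

The compounds with two trifluoromethyl groups on the aryl ring also differ from compound 3 and compound 4 in their other parts, so the contribution of that ring remains unresolved. Going by these compounds, whether a pyridine ring or a carboxylic acid at this position would shift the number also remains open.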